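Aryl swap at the biphenyl terminus: pyrazole for pyridine

The source may hold more compounds than are shown below. What is called first, only, known or untested is meant among the compounds shown, and "the series" means these compounds.

In a functional assay on MV4-11 cells (Homo sapiens) for antiproliferative activity, with a stated time of 6 days, tested at 6.25 uM (a higher number here means a stronger effect of the compound at the concentration tested, a lower number a weaker effect), the measured compounds stand as follows. Compound 1 `CNC(=O)N1CCCc2ccc(NC(=O)c3ccc(-c4ccccc4)cc3)cc21` gives 74.3%. Compound 2 `CNC(=O)N1CCCc2ccc(NC(=O)c3ccc(-c4cnn(C(C)=O)c4)cc3)cc21` gives 83.8%. Compound 3 `CNC(=O)N1CCCc2ccc(NC(=O)c3ccc(-c4ccccn4)cc3)cc21` gives 79.2%.

Compound 3 sits between the other two on the numbers shown, with both neighbours within the scatter: a number 4.9 percentage points higher from compound 1 to compound 3 (within the scatter) and a number 4.6 percentage points lower from compound 2 to compound 3 (within the scatter). All three aryl replacements on this shared core so far read as one plateau.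

Compound 4 `CNC(=O)N1CCCc2ccc(NC(=O)c3ccc(-c4cn[nH]c4)cc3)cc21` differs from compound 3 by 1H-pyrazol-4-yl in place of pyridin-2-yl on an aromatic carbon. Among the compounds with values here, the steps that bear on it are the two replacements of the terminal ring above, neither of which left the scatter, including a number 9.5 percentage points higher from compound 1 to compound 2 (within the scatter). In this assay the expected step is therefore a number 0.8 percentage points higher from compound 3 to compound 4 (within the scatter), none beyond the scatter. Compound 4 is estimated at 80%, with a range from 68% to 90%.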

Compound 4, a percentage reported as inhibition, at one concentration (the size of the read-out at that concentration, not a potency): 98.3%
Beside the measured number, compound 4's estimate is 18.3 percentage points below it; the whole stated range lies below it.
By their numbers in this assay, from the lowest: compounds 1, 3 and 2 (each within the scatter of the next); then compound 4.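

In this assay, the terminal ring at this position no longer reads as a plateau: 1H-pyrazol-4-yl stands apart from the other rings, with a number 19.1 percentage points higher from compound 3 to compound 4 (beyond the scatter) and a number 24 percentage points higher from compound 1 to compound 4 (beyond the scatter). Hydrogen in place of acetyl on the aromatic nitrogen also matters, with a number 14.5 percentage points higher from compound 2 to compound 4 (beyond the scatter), and unlike pyridin-2-yl, the entering ring carries a hydrogen-bond donor. No measured evidence accounts for these steps.

Open, as far as these compounds go, is whether a methyl group or a longer chain on that pyrazole nitrogen would keep the higher number. A single tested concentration also gives no potency.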